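This account rests on a few compounds, and the source may have more. Where it says the series, first, only, none or still open, it means among the compounds named here.

Three compounds have been measured in a functional assay on A549 cells (Homo sapiens) for antiproliferative activity, read by MTT assay, with a stated time of 24 h; on this read-out higher numbers stand for weaker inhibition and lower numbers for stronger inhibition:

Compound 1 `COc1cc(-c2cc(C(=O)/C=C/c3ccc(Cl)cc3)nc3cc(-c4ccccc4)nn23)cc(OC)c1OC` gives 23800 nM.
Compound 2 `COc1ccc(/C=C/C(=O)c2cc(-c3cc(OC)c(OC)c(OC)c3)n3nc(-c4ccccc4)cc3n2)cc1OC` gives 20500 nM.
Compound 3 `COc1ccc(C(=O)/C=C/c2cc(-c3cc(OC)c(OC)c(OC)c3)n3nc(-c4ccccc4)cc3n2)cc1OC` gives 17800 nM.

All three carry a trimethoxyphenyl group and a phenyl group on a shared core, and a three-carbon chain with a carbonyl and a double bond leading to a further aromatic ring. Compounds 2 and 3 are built from the same atoms joined differently; the difference between the two cores is not broken down here. Their values in this assay sit within the usual scatter of each other, so nothing can be said about which is stronger.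

Compound 1 differs from compound 2 by one change: 4-chlorophenyl in place of 3,4-dimethoxyphenyl on a double-bonded chain carbon bound to a double-bonded chain carbon. That change gave a 1.2-fold higher number from compound 2 to compound 1 (0.06 log units; within the scatter).

The unmeasured compound 4 `COc1cc(-c2cc(/C=C/C(=O)c3ccc(Cl)cc3)nc3cc(-c4ccccc4)nn23)cc(OC)c1OC` is related to compound 3 by the same kind of change: 4-chlorophenyl in place of 3,4-dimethoxyphenyl on a carbonyl carbon. The place is not the same word for word: in compound 2 the group sits on a double-bonded chain carbon bound to a double-bonded chain carbon, whereas in compound 3 it sits on a carbonyl carbon whose other neighbour is a double-bonded chain carbon.

Going by the values given here, since the comparable change from compound 2 to compound 1 stayed within the scatter, a step of about the same size is expected here, a 1.2-fold higher number from compound 3 to compound 4 (0.07 log units; within the scatter), because the only guide is a 1.2-fold higher number from compound 2 to compound 1 (0.06 log units; within the scatter). For compound 4 the estimate in this assay is 21000 nM, with a likely range from 10000 nM to 45000 nM.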

Compound 4, half-maximal inhibitory concentration: 15500 nM
The estimate for compound 4 lay 1.4-fold (0.13 log units) above the measured number; low and high end bracket the measured number.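

In this assay, 4-chlorophenyl in place of 3,4-dimethoxyphenyl on a carbonyl carbon gave a 1.1-fold lower number from compound 3 to compound 4 (0.06 log units; within the scatter), while 2-((4-chlorophenyl)carbonyl)ethenyl in place of (2-(4-chlorophenyl)ethenyl)carbonyl on an aromatic carbon gave a 1.5-fold lower number from compound 1 to compound 4 (0.19 log units; within the scatter). Neither step can be told apart from the ordinary spread of repeated measurements, and the swap of the two aromatic groups looks alike on both cores as far as this read-out can tell: the same change on two cores in this assay, a 1.2-fold higher number (0.06 log units; within the scatter) from compound 2 to compound 1 and a 1.1-fold lower number (0.06 log units; within the scatter) from compound 3 to compound 4, 1.3-fold (0.12 log units) apart, within the scatter of two such steps This agreement is only a weak test of whether the change carries from one core to another, since neither step shows that the swap does anything measurable, and two steps that both stay within the scatter would look alike even if the cores responded somewhat differently.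

The compounds shown leave open whether a ring bearing an amine or a carboxylic acid, in place of 4-chlorophenyl, would give a step beyond the scatter on either core. They also leave open whether a longer chain in place of the present one, carrying the carbonyl and the double bond, would do so.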